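Benzyl ether variation on the shared core, antiproliferative series

The source may report more compounds than this note shows. Statements on the series, on what has been measured and on what is new or still open speak of the compounds shown alone.

Measured so far:
compound 1 `COc1ccc2c(=O)c(-c3cc(OC)c(OC)cc3OC)coc2c1`: 9170 nM
compound 2 `COc1cc(OC)c(-c2coc3cc(OCc4ccccc4C(F)(F)F)ccc3c2=O)cc1OC`: 4760 nM

In a functional assay on HCT-116 cells (Homo sapiens) for antiproliferative activity, read by MTT assay, with a stated time of 24 h (on this read-out lower numbers stand for stronger inhibition and higher numbers for weaker inhibition), compound 1 gives 9170 nM and compound 2 gives 4760 nM. For the measured compounds named here, the single recorded step, a 1.9-fold lower number from compound 1 to compound 2 (0.28 log units; within the scatter), adds 2-(trifluoromethyl)phenyl in place of hydrogen on a saturated chain carbon bound to an oxygen on an aromatic ring; it stays inside the scatter, so compound 2 and compound 1 cannot be told apart on these two numbers, and neither can be called the more active.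

Compound 3 `COc1cc(OC)c(-c2coc3cc(OCc4cccc(Br)c4)ccc3c2=O)cc1OC` is not yet measured. It differs from compound 2 by 3-bromophenyl in place of 2-(trifluoromethyl)phenyl on a saturated chain carbon bound to an oxygen on an aromatic ring. Going by the values given here, no measured pair varies the group on this benzylic position, so the only step that bears on compound 3 is the one from compound 1 to compound 2, and that step was itself within the scatter. The change keeps one six-membered aromatic ring of carbon only in the same place, with no hydrogen-bond donors or acceptors leaving or entering. The expectation is therefore no step beyond the scatter: compound 3 is estimated at 4800 nM, range 2000 nM to 11000 nM, which means an expected step of a 1.0-fold higher number from compound 2 to compound 3 (0.00 log units; within the scatter).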

Compound 3, half-maximal inhibitory concentration: 1200 nM
Beside the measured number, compound 3's estimate is 4.0-fold (0.60 log units) above it; measured number below the stated range.
By their numbers in this assay, from the lowest: compound 3; then compounds 2 and 1 (each within the scatter of the next).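

In this assay, for the compounds shown here, the saturated chain carbon bound to an oxygen on an aromatic ring now proves sensitive to which aryl group it carries: 3-bromophenyl in place of 2-(trifluoromethyl)phenyl gives a 4.0-fold lower number from compound 2 to compound 3 (0.60 log units; beyond the scatter), the first step to clear the scatter. Measured against hydrogen at this place, 3-bromophenyl gives a 7.6-fold lower number from compound 1 to compound 3 (0.88 log units; beyond the scatter), whereas 2-(trifluoromethyl)phenyl gave only a 1.9-fold lower number from compound 1 to compound 2 (0.28 log units; within the scatter), so an aryl group here can shift the number measurably, but not every aryl group does. Nothing on hand accounts for the difference between these two groups.

The two aryl groups differ both in their substituent and in where it stands on the ring, and the compounds shown do not separate these two changes, so the step cannot be assigned to bromine itself or to its placement. Going by these compounds, it also remains open how this place responds to a ring carrying an amine or a carboxylic acid, or to a longer chain in place of 3-bromobenzyl.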